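Amide Variation on a Stilbene-Acrylamide Scaffold

The source may hold more compounds than are shown below. What is called first, only, known or untested is meant among the compounds shown, and "the series" means these compounds.

Measured compounds:
Compound 1, `COc1ccc(/C=C/c2cc(OC)cc(OC)c2/C=C/C(=O)NC2CC2)cc1`: 3940 nM
Compound 2, `COc1ccc(/C=C/c2cc(OC)cc(OC)c2/C=C/C(=O)N2CCCC2)cc1`: 4200 nM

Both compounds were tested in a functional assay on MCF7 cells (Homo sapiens) for inhibition, read by MTT assay, with a stated time of 48 h; a lower number here means a stronger inhibitor, a higher number a weaker inhibitor. Compound 1 and compound 2 share the same core and differ only in the group on the carbonyl carbon; the step of a 1.1-fold higher number from compound 1 to compound 2 (0.03 log units; within the scatter) is within the scatter, so the two numbers sit together and compound 1 stands level with compound 2 rather than apart from it.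

The unmeasured compound 3, `COc1ccc(/C=C/c2cc(OC)cc(OC)c2/C=C/C(=O)N(CC(C)C)CC(C)C)cc1`, keeps the core of compound 1 and changes the same carbonyl position: diisobutylamino in place of cyclopropylamino on a carbonyl carbon. Within the data shown here, the only measured step that bears on this position is a 1.1-fold higher number from compound 1 to compound 2 (0.03 log units; within the scatter), where swapping one amine for another left the number essentially unchanged. On that single precedent the expectation is that compound 3 will again stay close to compound 1, with perhaps a slight drift to a higher number; the step of a 1.3-fold higher number from compound 1 to compound 3 (0.10 log units; within the scatter) is what is expected. Compound 3 is therefore estimated at 5000 nM, with a range from 2000 nM to 15000 nM.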

Compound 3, half-maximal inhibitory concentration: 2390 nM
Compound 3: middle estimate off by 2.1-fold (0.32 log units), on the high side; the measured number falls inside the stated range.
By their numbers in this assay, from the lowest: compounds 3, 1 and 2 (each within the scatter of the next).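

In this assay, diisobutylamino in place of cyclopropylamino gives a 1.6-fold lower number from compound 1 to compound 3 (0.22 log units; within the scatter), and diisobutylamino in place of pyrrolidin-1-yl gives a 1.8-fold lower number from compound 2 to compound 3 (0.24 log units; within the scatter), so all three amides sit together. The earlier pair compared only groups that carry a ring, whereas the group entering here has no ring and 9 heavy atoms against the 4 of cyclopropylamino, and it has 0 hydrogen-bond donors against 1. Even a change this large on the carbonyl carbon leaves compound 3 level with compound 1 and compound 2, which widens the range of amines known to read alike in this series beyond what the first two compounds could show.

The compounds shown leave open whether a different kind of group on this carbonyl carbon, such as a hydroxyl that would make a carboxylic acid, or a morpholin-4-yl or a plain unsubstituted amino group, would read apart from these three. Nothing available here explains why these three amines give such similar numbers.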